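Switching a small hydroxycyclobutyl ring for a larger cyclohexyl

The source may report more compounds than this note shows. Statements on the series, on what has been measured and on what is new or still open speak of the compounds shown alone.

Measured compounds:
compound 1, `N#Cc1cnc(NCc2cnccc2C(F)(F)F)cc1N[C@H]1C[C@@H](O)C1`: 500 nM
compound 2, `CC1(C)C[C@H](Nc2cc(NCc3cnccc3C(F)(F)F)ncc2C#N)CC(C)(C)[C@H]1O`: 20 nM
compound 3, `CC1(C)C[C@H](Nc2cc(NCc3cnccc3C(F)(F)F)ncc2C#N)CC[C@H]1O`: 100 nM

These three share one core and were all tested in an assay on isolated protein for inhibition of protein kinase C theta type (Homo sapiens), read by TR-FRET, with a stated time of 2 h; on this read-out higher numbers stand for weaker inhibition and lower numbers for stronger inhibition. Compound 1 gives the highest number of the three, so it is the weakest inhibitor here; compound 3 sits nearest to it, while compound 2 lies furthest away with the lowest number.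

Compound 4, `CC1(C)C[C@@H](Nc2cc(NCc3cnccc3C(F)(F)F)ncc2C#N)CC[C@H]1O`, has not been measured yet. It differs from compound 1 as follows: 4-hydroxy-3,3-dimethylcyclohexyl in place of 3-hydroxycyclobutyl on a nitrogen on an aromatic ring. Among the compounds with values here, the one measured step that bears directly on this change is a 5.0-fold lower number from compound 1 to compound 3 (0.70 log units; beyond the scatter), and the group entering there reads the same, in words, as the group entering in compound 4. Within the data shown here, the structures drawn above show what still keeps compound 3 and compound 4 apart, but no measured pair here tells how much that matters. The expectation therefore rests on the step to compound 3 alone, with extra room left for that uncertainty.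

On this basis, compound 4 is expected to give a lower number than compound 1, with a step of about a 3.3-fold lower number from compound 1 to compound 4 (0.52 log units; beyond the scatter). The estimate for compound 4 is 150 nM, expected to fall between 40 nM and 600 nM.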

Compound 4, half-maximal inhibitory concentration: 120 nM
Estimate against measurement, compound 4: 1.3-fold (0.10 log units) above, within the range that was stated.
By their numbers in this assay, from the lowest: compound 2; then compounds 3 and 4 (each within the scatter of the next); then compound 1.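

In this assay, the larger ring lowers the number in a second compound: 4-hydroxy-3,3-dimethylcyclohexyl in place of 3-hydroxycyclobutyl gives a 4.2-fold lower number from compound 1 to compound 4 (0.62 log units; beyond the scatter), and the earlier step was a 5.0-fold lower number from compound 1 to compound 3 (0.70 log units; beyond the scatter). The new information concerns the stereocentre at a saturated ring carbon, where the change in configuration gives a 1.2-fold higher number from compound 3 to compound 4 (0.08 log units; within the scatter), so no effect of that centre can be read in this assay and the drop from compound 1 does not rest on one drawn form alone. This comparison tests that single centre because of what sets the two compounds apart: the fact that compounds 3 and 4 differ only in the configuration as drawn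

The other stereocentre of the 4-hydroxy-3,3-dimethylcyclohexyl group remains untested, and the compounds shown do not tell how an amine or a methoxy group in place of the hydroxy group would compare. Within the data shown here, compound 2 gives 20 nM, the lowest number here, but no single-place step connects it to the other compounds, so what it adds to this series stays open.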